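Adding a ring methyl to the compound with the lowest dipeptidyl peptidase 4 inhibition

The source may report more compounds than this note shows. Statements on the series, on what has been measured and on what is new or still open speak of the compounds shown alone.

Measured compounds:
compound 1, `CCN(C)C(=O)[C@H]1C[C@@H](C(=O)N2CCC[C@H]2C#N)N[C@H]1C`, 74%
compound 2, `C[C@@H]1N[C@H](C(=O)N2CCC[C@H]2C#N)C[C@@H]1C(=O)N1CCCC1`, 82%
compound 3, `CN(C)C(=O)[C@@H]1CN[C@H](C(=O)N2CCC[C@H]2C#N)C1`, 24%

In an assay on the whole organism (plasma, strain Sprague-Dawley) for inhibition of Dipeptidyl peptidase 4 (Rattus norvegicus), with a stated time of 12 h, at a dose of 1 mg/kg by the oral route (a higher number here means more inhibition at the dose given (going by the name of the read-out), a lower number less inhibition), compound 3 gives 24%, the lowest of the three numbers, beyond the scatter below both others. Compound 4 is `C[C@@H]1N[C@H](C(=O)N2CCC[C@H]2C#N)C[C@@H]1C(=O)N(C)C`; it differs from compound 3 by methyl in place of hydrogen on a saturated ring carbon. For the measured compounds named here, no measured step changes this position directly. Going by the values given here, the one measured step, a number 8 percentage points higher from compound 1 to compound 2 (within the scatter), shows only that swapping the amide substituent barely matters. Compound 4 carries the same ring methyl as compound 1 and compound 2, and its amide is closest to that of compound 1, so compound 4 is expected to rise by a number 46 percentage points higher from compound 3 to compound 4 (beyond the scatter). Compound 4 is therefore estimated at 70%, between 45% and 88%.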

Compound 4, a percentage reported as inhibition, in the whole organism at one dose (the size of the read-out at that dose, not a potency): 81%
Estimate against measurement, compound 4: 11 percentage points below, and the stated range covers the measured number.
By their numbers in this assay, from the lowest: compound 3; then compounds 1, 4 and 2 (each within the scatter of the next).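

In this assay, for the compounds shown here, methyl in place of hydrogen on this saturated ring carbon is the only one-place change so far with a step beyond the scatter (a number 57 percentage points higher from compound 3 to compound 4 (beyond the scatter)). With that methyl present, changing the amide group stays within the scatter, both for dimethylamino in place of pyrrolidin-1-yl (a number 1 percentage points lower from compound 2 to compound 4 (within the scatter)) and for dimethylamino in place of ethyl(methyl)amino (a number 7 percentage points higher from compound 1 to compound 4 (within the scatter)). Nothing available explains what the methyl does here.

Going by these compounds, whether an ethyl or a hydroxymethyl group on this ring carbon would give a similar number remains open. Going by these compounds alone, the methyl step is also seen only with the dimethylcarbamoyl group, so its size with a pyrrolidin-1-yl amide is unknown.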